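Working notes: the step from compound 3 to compound 4

A few compounds are considered here, and "the series" means these few. Any claim that something is new, unique, unknown or untested is made for them only; others in the source may bear on it.

Values in a functional assay on OVCAR-3 cells (Homo sapiens) for cytotoxicity, read by sulforhodamine B assay; a higher number here means a weaker inhibitor of growth, a lower number a stronger inhibitor of growth:
- compound 1 `CC1=CC[C@@H]([C@@](C)(O)CCCC(C)(C)NC=S)CC1`: 12100 nM
- compound 2 `CC1=CC[C@@H]([C@@](C)(O)CCCC(C)(C)NC(=S)NN)CC1`: 17200 nM
- compound 3 `COc1ccc(/C=N\NC(=S)NC(C)(C)CCC[C@](C)(O)[C@@H]2CC=C(C)CC2)cc1`: 6500 nM

Compound 3 sits at the low end of these values, within the scatter of compound 1 and beyond it from compound 2. Compound 4 `CC1=CC[C@@H]([C@@](C)(O)CCCC(C)(C)NC(=S)N/N=C\c2cccc([N+](=O)[O-])c2)CC1` differs from compound 3 in one group: 3-nitrophenyl in place of 4-methoxyphenyl on a carbon with a double bond to nitrogen. Going by the values given here, only one measured step adds a group at this place, the modest 2.6-fold lower number from compound 2 to compound 3 (0.42 log units; beyond the scatter). The other, a 1.4-fold higher number from compound 1 to compound 2 (0.15 log units; within the scatter), stays within the scatter. Among the compounds with values here, no measured pair exchanges one such ring group for another, so no direction is settled and no change beyond the scatter is expected in this assay. The expected step is a 1.2-fold lower number from compound 3 to compound 4 (0.07 log units; within the scatter). The estimate for compound 4 is 5500 nM, with an expected range of 2300 nM to 13000 nM.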

Compound 4, concentration for 50% growth inhibition: 8510 nM
Estimate against measurement, compound 4: 1.5-fold (0.19 log units) below; the range from low to high includes it.
By their numbers in this assay, from the lowest: compounds 3, 4, 1 and 2 (each within the scatter of the next, the first and the last beyond it).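

In this assay, one ring group is now exchanged directly for another on a carbon with a double bond to nitrogen. 3-nitrophenyl in place of 4-methoxyphenyl gives a 1.3-fold higher number from compound 3 to compound 4 (0.12 log units; within the scatter), so this pair does not separate the two groups. Nothing measured bears on why they read alike.

Still open, as far as these compounds go, is whether a plain phenyl, a pyridine ring or a phenyl carrying a carboxylic acid at this place would give a step beyond the scatter. Also open, from the compounds shown here alone, is whether an amine in place of the whole ring group would do so.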